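This account rests on a few compounds, and the source may have more. Where it says the series, first, only, none or still open, it means among the compounds named here.

In a functional assay on A549 cells (Homo sapiens) for inhibition, read by MTT assay, with a stated time of 72 h (a higher number here means a weaker inhibitor, a lower number a stronger inhibitor), compound 3 `CC1=NN(c2ccc(C)cc2)C(=O)[C@]12C(=O)C=CC[C@H]2c1ccc(C)cc1` gives 7520 nM. That is the same level, within the usual scatter, as compound 2 `CC1=NN(c2ccccc2)C(=O)[C@@]12C(=O)C=CC[C@@H]2c1ccc(C)cc1` at 6570 nM, while compound 1 `CC1=NN(c2ccccc2)C(=O)[C@]12C(=O)C=CC[C@H]2c1ccc(C)cc1` has the lowest number of the three at 2890 nM. The next molecule, compound 4 `CC1=NN(c2ccc(C)cc2)C(=O)[C@@]12C(=O)C=CC[C@@H]2c1ccc(C)cc1`, is the mirror image of compound 3: the two compounds have the same atoms and bonds and differ only in configuration as drawn: 2 of 2 stereo elements differ (all stereocentres are inverted: mirror images); a stereocentre at a saturated ring carbon is drawn S in compound 3 and R in compound 4; a stereocentre at a saturated ring carbon is drawn S in compound 3 and R in compound 4. No atom is added or removed, so only the handedness of the molecule changes.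

One measured step makes the same kind of change: a 2.3-fold higher number from compound 1 to compound 2 (0.36 log units; beyond the scatter). That step rests on (the fact that compounds 1 and 2 differ only in the configuration as drawn), and the inversion runs the same way, from S to R at both stereocentres. The other step, a 2.6-fold higher number from compound 1 to compound 3 (0.42 log units; beyond the scatter), comes from a methyl in place of hydrogen on an aromatic carbon. It sets the higher starting point of compound 3 but says nothing directly about handedness.

Within the data shown here, with only one mirror-image pair as a guide, the safest expectation is a modest step towards a higher number in this assay, similar in size to the step seen with compound 2. The expected change is a 2.1-fold higher number from compound 3 to compound 4 (0.33 log units; beyond the scatter). For compound 4 the estimated value is 16000 nM, with an expected range from 7000 nM to 32000 nM.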

Compound 4, half-maximal inhibitory concentration: 4320 nM
The estimate for compound 4 lay 3.7-fold (0.57 log units) above the measured number; the measured number lies below the stated range.
By their numbers in this assay, from the lowest: compounds 1, 4, 2 and 3 (each within the scatter of the next, the first and the last beyond it).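

In this assay, among these compounds, the mirror-image change, made with the aromatic methyl present, gives a 1.7-fold lower number from compound 3 to compound 4 (0.24 log units; within the scatter), so handedness no longer separates this pair as clearly as it separated the pair without that methyl, which showed a 2.3-fold higher number from compound 1 to compound 2 (0.36 log units; beyond the scatter). The methyl change can now also be read on both mirror-image forms of the core: one form gives a 1.5-fold lower number from compound 2 to compound 4 (0.18 log units; within the scatter), while the other gave a 2.6-fold higher number from compound 1 to compound 3 (0.42 log units; beyond the scatter). The result of placing a methyl on this aromatic carbon therefore differs with the handedness of the core that carries it: the same change on two cores in this assay, a 2.6-fold higher number (0.42 log units; beyond the scatter) from compound 1 to compound 3 and a 1.5-fold lower number (0.18 log units; within the scatter) from compound 2 to compound 4, 4.0-fold (0.60 log units) apart, beyond the scatter of two such steps.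

The compounds shown compare only hydrogen and methyl at this place, so it remains open whether a chlorine, a methoxy group, an amine or a carboxylic acid would also give different results on the two mirror-image forms. Going by these compounds, with just two mirror-image pairs, and all numbers falling within a narrow span, it also remains open whether this dependence on handedness would hold for other groups or on other parts of the shared core.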